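The source may report more compounds than this note shows. Statements on the series, on what has been measured and on what is new or still open speak of the compounds shown alone.

Compound 1 `O=C(CSc1nnc(NC(=O)CCl)s1)Nc1ccc(Cl)cn1` and compound 3 `O=C(CCl)Nc1ccc(SCC(=O)Nc2ccc(Cl)cn2)cc1` share a chloromethyl carbonyl amino group on different cores, and the difference between the two cores is not broken down here. In a functional assay on HeLa cells (Homo sapiens) for antiproliferative activity, read by MTT assay, with a stated time of 48 h (a lower number here means a stronger inhibitor, a higher number a weaker inhibitor), compound 1 gives 3600 nM. In this assay compound 3 gives 2500 nM, and its number is the lowest of the two numbers recorded, though the gap to compound 1 lies within the usual scatter, so no order between them can be stated.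

Compound 2 `O=C(CSc1nnc(NC(=O)CCCCl)s1)Nc1ccc(Cl)cn1` carries the change (2-chloroethyl in place of chloro on a saturated chain carbon bound to a carbonyl carbon). In this assay compound 2 reaches only a limit of the assay, > 80000 nM, which is the limit of > 80000 nM in this assay, at which 1 of the 3 values shown sits. The step of an at least 22-fold higher number from compound 1 to compound 2 (1.34 log units; beyond the scatter) is therefore large and lies beyond the scatter.

Compound 4 `O=C(CCCCl)Nc1ccc(SCC(=O)Nc2ccc(Cl)cn2)cc1` is not yet measured. Among the compounds with values here, it differs from compound 3 by 2-chloroethyl in place of chloro on a saturated chain carbon bound to a carbonyl carbon, which is the same change, at the same place, as the one that separates compound 1 from compound 2. Because the earlier step of an at least 22-fold higher number from compound 1 to compound 2 (1.34 log units; beyond the scatter) was a large loss, compound 4 is expected to show a comparable loss against compound 3, with the estimated step of a 24-fold higher number from compound 3 to compound 4 (1.38 log units; beyond the scatter). Since compound 3 starts from a somewhat lower number than compound 1, the estimate for compound 4 in this assay is 60000 nM, within a range from 15000 nM to 200000 nM, with a real chance that the assay again returns only a limit.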

Compound 4, half-maximal inhibitory concentration: > 80000 nM
Compound 4: no number, only a limit; the forecaster's own chance of this, stated with the estimate: 55%; at least 1.3-fold (0.12 log units) between middle value and limit.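

In this assay compound 4 gives > 80000 nM, which is a limit of the assay and not a number. Within the data shown here, the step from chloromethyl to 3-chloropropyl on this second core is large, an at least 32-fold higher number from compound 3 to compound 4 (1.50 log units; beyond the scatter), so the loss seen on the core of compound 1 appears again on the core of compound 3, and of four compounds no pair goes against that direction. What this does not show is how large the loss really is on either core, or whether the two cores respond to the same degree, since both of the longer compounds stop at a limit and only lower bounds on the steps can be stated: the same change on two cores in this assay, an at least 22-fold higher number (1.34 log units; beyond the scatter) from compound 1 to compound 2 and an at least 32-fold higher number (1.50 log units; beyond the scatter) from compound 3 to compound 4; the limit leaves it open whether they differ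

The compounds shown leave open where along the chain the loss sets in, as a (2-chloroethyl)carbonyl group would fall short of the 3-chloropropyl chain, and the true numbers of compound 2 and compound 4 remain unknown. They also leave open whether the chlorine itself matters, which a plain methyl or an amine in place of chloromethyl on either core would address.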